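Swapping a bromo for an ester-bearing chain

This account rests on a few compounds, and the source may have more. Where it says the series, first, only, none or still open, it means among the compounds named here.

Of the compounds shown here, three have been measured in an assay on isolated protein with Bile acid receptor (Homo sapiens) as the target; on this read-out higher numbers stand for an effect only at larger amounts of compound and lower numbers for an effect already at smaller amounts. Compound 1 `COC(=O)/C=C/c1cccc(N(Cc2ccc(-c3cccc(C)c3)cc2)C(=O)C2CCCCC2)c1` gives 109 nM. Compound 2 `COC(=O)/C=C/c1cccc(N(Cc2ccccc2)C(=O)C2CCCCC2)c1` reaches only the limit of this assay, > 1000 nM. Compound 3 `COC(=O)/C=C/c1cccc(N(Cc2ccc(Br)cc2)C(=O)C2CCCCC2)c1` likewise stops at the limit, > 1000 nM, so it stands at a limit rather than a number, as one other value does (the limit of > 1000 nM in this assay, at which 2 of the 3 values shown sit). Compound 4 `CCOC(=O)/C=C/c1ccc(CN(C(=O)C2CCCCC2)c2cccc(/C=C/C(=O)OC)c2)cc1` differs from compound 3 by one change: 2-(ethoxycarbonyl)ethenyl in place of bromo on an aromatic carbon. Within the data shown here, the steps that bear on it are an at least 9.1-fold higher number from compound 1 to compound 3 (0.96 log units; beyond the scatter) and an at least 9.1-fold higher number from compound 1 to compound 2 (0.96 log units; beyond the scatter), both ending at the limit where the 3-methylphenyl of compound 1 is lost. The entering group is large but carries no ring, so a modest move toward smaller numbers is expected; the step estimated is an at least 1.6-fold lower number from compound 3 to compound 4 (0.22 log units; that floor lies within the scatter). Compound 4 is estimated at 600 nM, between 150 nM and 3000 nM.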

Compound 4, half-maximal effective concentration: > 1000 nM
Compound 4: a limit, no number (the forecaster's own chance of this, stated with the estimate: 35%); at least 1.6-fold (0.22 log units) between middle value and limit.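

With 2-(ethoxycarbonyl)ethenyl in place of 3-methylphenyl on this aromatic carbon, the result is an at least 9.1-fold higher number from compound 1 to compound 4 (0.96 log units; beyond the scatter). A large group without a ring therefore does not recover the measurable effect of compound 1, and among the groups shown here, only 3-methylphenyl gives a number rather than a limit. Steps among compound 2, compound 3 and compound 4 cannot be read, and compound 4 also stands at a limit: the limit of > 1000 nM in this assay, at which 3 of the 4 values shown sit.

As far as these compounds go, whether a ring at this position is what matters stays open. An unsubstituted phenyl, or a carboxylic acid in place of the ethyl ester, would help to separate these possibilities.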